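A few compounds are considered here, and "the series" means these few. Any claim that something is new, unique, unknown or untested is made for them only; others in the source may bear on it.

Working notes on the series.

The series rests on a shared core that compound 1 `CCCCCOc1nc(N)c2nc(O)n(Cc3ccccc3)c2n1` shows, with a pentyloxy group and a hydroxy group on the fused rings. In a functional assay (spleen, spleen) for activation, with Mus musculus as the target (a lower number here means that less compound is needed, a higher number that more compound is needed for the effect), compound 1 gives 0.01 uM. Compound 2 `NNc1nc2c(N)ncnc2n1Cc1ccccc1` carries aminoamino on the aromatic carbon. In this assay compound 2 reaches only the limit of the assay, > 10 uM. Compound 3 `CSc1nc2c(N)ncnc2n1Cc1ccccc1` carries methylsulfanyl at the same carbon. In this assay compound 3 likewise stops at the limit, > 10 uM. The step that the two limits leave unreadable from compound 2 to compound 3 therefore cannot be read, and compound 3 stands with compound 2 at the limit of > 10 uM in this assay, at which 2 of the 3 values shown sit, far from the number seen for compound 1.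

Compound 4 `Cc1nc2c(N)ncnc2n1Cc1ccccc1` differs from compound 3 by methyl in place of methylsulfanyl on an aromatic carbon. Within the data shown here, no measured step bears directly on this exchange: the only pair that differs in one place, compound 2 to compound 3, is unreadable, and compound 1 differs in several places. With compound 3 at the limit, no movement beyond the scatter can be expected in this assay from the step that the limit leaves unreadable from compound 3 to compound 4. Compound 4 is accordingly estimated at 20 uM, within 3 uM to 100 uM, most likely again reported as a limit.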

Compound 4, minimum effective concentration: > 10 uM
Compound 4 ended at the assay's limit; the forecaster's own chance of this, stated with the estimate: 70%; the middle value does not contradict the limit.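

Compound 2, compound 3 and compound 4 all stop at a limit in this assay, so no step among them can be read: the limit of > 10 uM in this assay, at which 3 of the 4 values shown sit.

The compounds shown leave open whether aminoamino, methylsulfanyl and methyl on this aromatic carbon differ at all in this assay, and which of the several differences from compound 1 matters.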